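The source may hold more compounds than are shown below. What is called first, only, known or untested is meant among the compounds shown, and "the series" means these compounds.

Measured so far in a functional assay on K562 cells (Homo sapiens) for cytotoxicity, read by sulforhodamine B assay, with a stated time of 48 h; on this read-out higher numbers stand for lower toxicity in this test and lower numbers for higher toxicity in this test:
compound 1 `ClCc1ccccc1Cn1cnc2c(Cl)nc(Cl)nc21` — 910 nM
compound 3 `ClCc1cccc(Cn2cnc3c(Cl)ncnc32)c1` — 75900 nM
compound 2 `ClCc1cccc(Cn2cnc3ncnc(Cl)c32)c1` — > 100000 nM, which is a limit of the assay and not a number

Compound 3 stands at the highest of the two numbers in this assay; the nearest, compound 1, lies well below it, a gap beyond the usual scatter. For compound 2 only a limit is reported (the limit of > 100000 nM in this assay, at which 1 of the 3 values shown sits).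

Compound 4 `ClCc1cccc(Cn2cnc3c(Cl)nc(Cl)nc32)c1` differs from compound 3 by chloro in place of hydrogen on an aromatic carbon. Within the data shown here, no measured pair shows this change on its own. Among the measured compounds shown here, compound 1, the only compound carrying two chloro groups on the shared core, gives the lowest number, yet it also differs from compound 4 in how the benzyl part is substituted, so the two points cannot be separated. A lower number is expected in this assay, of a size that goes beyond the scatter, though short of the value of compound 1. The step expected from compound 3 to compound 4 is an 8.4-fold lower number from compound 3 to compound 4 (0.93 log units; beyond the scatter). Compound 4 is thus estimated at 9000 nM, between 1500 nM and 45000 nM.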

Compound 4, concentration lethal to 50% of the cells: > 100000 nM
Compound 4: only a limit was reported; the forecaster's own chance of this, stated with the estimate: 10%; middle value at least 11-fold (1.04 log units) from the limit.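

In this assay, chloro in place of hydrogen on the aromatic carbon between two ring nitrogen atoms gives an at least 1.3-fold higher number from compound 3 to compound 4 (0.11 log units; that floor lies within the scatter), so this change brings no lower number, and the true size of the step cannot be read. The value of compound 4, > 100000 nM, is a limit of the assay and not a number, and compound 2 sits at the same limit: the limit of > 100000 nM in this assay, at which 2 of the 4 values shown sit. Two chloro groups on the shared core are therefore not enough for a low number here: compound 1 gives 910 nM and differs from compound 4 in how the benzyl part is substituted.

Open, going by these compounds, is whether that benzyl substitution alone accounts for the value of compound 1. Also open, on these data alone, is how an amine or a methoxy group at this position would read.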